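Hydroxycarbamoyl tail, chain to phenyl, in two pairings

This account rests on a few compounds, and the source may have more. Where it says the series, first, only, none or still open, it means among the compounds named here.

Measured so far:
compound 1 `CCOc1cc(C(C)(C)C)ccc1C1=NC(c2ccc(Cl)cc2)C(c2ccc(Cl)cc2)N1C(=O)NCCCCCCCC(=O)NO` gives 9060 nM
compound 2 `CCOc1cc(C(C)(C)C)ccc1C1=NC(c2ccc(Cl)cc2)C(c2ccc(Cl)cc2)N1C(=O)N1CCN(Cc2ccc(C(=O)NO)cc2)CC1` gives 3000 nM
compound 3 `CCOc1cc(C(C)(C)C)ccc1C1=NC(c2ccc(Cl)cc2)C(c2ccc(Cl)cc2)N1C(=O)N1CCN(CCCCCCCC(=O)NO)CC1` gives 7760 nM

All three numbers come from a functional assay on NCI-H1299 cells (Homo sapiens) for antiproliferative activity, read by CCK-8 assay, with a stated time of 72 h; a lower number here means a stronger inhibitor, a higher number a weaker inhibitor. Compound 1 and compound 3 lie within the scatter of each other; the difference between their two cores is not broken down here. Between compound 3 and compound 2 the change is 4-(hydroxycarbamoyl)phenyl in place of 6-(hydroxycarbamoyl)hexyl on a saturated chain carbon bound to an amine nitrogen in a ring, and it made a 2.6-fold lower number from compound 3 to compound 2 (0.41 log units; beyond the scatter).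

Compound 4 `CCOc1cc(C(C)(C)C)ccc1C1=NC(c2ccc(Cl)cc2)C(c2ccc(Cl)cc2)N1C(=O)NCc1ccc(C(=O)NO)cc1` is not yet measured. It differs from compound 1 by 4-(hydroxycarbamoyl)phenyl in place of 6-(hydroxycarbamoyl)hexyl on a saturated chain carbon bound to an amide-type nitrogen. This is the same kind of change as the measured one, not the same: in compound 3 the place is a saturated chain carbon bound to an amine nitrogen in a ring, in compound 1 a saturated chain carbon bound to an amide-type nitrogen. Within the data shown here, with only that single instance to go on, the step is expected to be a 2.6-fold lower number from compound 1 to compound 4 (0.41 log units; beyond the scatter), resting on a 2.6-fold lower number from compound 3 to compound 2 (0.41 log units; beyond the scatter). Compound 4 is therefore estimated at 3500 nM in this assay, with a plausible range from 1500 nM to 8500 nM.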

Compound 4, half-maximal inhibitory concentration: 7710 nM
Estimate against measurement, compound 4: 2.2-fold (0.34 log units) below, and the stated range covers the measured number.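

On a saturated chain carbon bound to an amide-type nitrogen, 4-(hydroxycarbamoyl)phenyl in place of 6-(hydroxycarbamoyl)hexyl gives a 1.2-fold lower number from compound 1 to compound 4 (0.07 log units; within the scatter) in this assay, so on this core the change has no readable effect. Set beside the earlier step, the two cores cannot be told apart: the same change on two cores in this assay, a 2.6-fold lower number (0.41 log units; beyond the scatter) from compound 3 to compound 2 and a 1.2-fold lower number (0.07 log units; within the scatter) from compound 1 to compound 4, 2.2-fold (0.34 log units) apart, within the scatter of two such steps. Among these compounds, this does not show that the change has one shared size on both cores, nor that it differs between them, since each core offers only a single pair.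

The compounds shown leave open how a shorter or longer chain bearing the same hydroxycarbamoyl end behaves on either core. Also open, on these data alone, is whether a carboxylic acid in place of the hydroxycarbamoyl group moves these numbers at all.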